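Swapping a phenol ring for a silicon group on the triazole

The compounds below may be only part of what the source reports. "The series", "measured", "known", "first", "only" and "open" are said of these compounds alone.

Compound 1 `O=C1O/C(=C\Cn2cc(-c3cc(F)cc(F)c3)nn2)C(OCc2ccccc2)=C1OCc1ccccc1`: > 100000 nM
Compound 2 `O=C1O[C@H]([C@@H](O)Cn2cc(-c3cccc(O)c3)nn2)C(OCc2ccccc2)=C1OCc1ccccc1`: > 100000 nM
Compound 3 `O=C1O[C@H]([C@@H](O)Cn2cc(CNS(=O)(=O)c3ccc(Cl)cc3F)nn2)C(OCc2ccccc2)=C1OCc1ccccc1`: 42400 nM

In a functional assay on SW-620 cells (Homo sapiens) for antiproliferative activity, read by MTT assay, with a stated time of 72 h (a lower number here means a stronger inhibitor, a higher number a weaker inhibitor), compound 1 gives > 100000 nM, which is a limit of the assay and not a number. Compound 2 likewise gives > 100000 nM, again a limit rather than a measured value. Only compound 3, with its sulfonamide side chain, gives an actual number, 42400 nM, so the series as a whole sits at or near the weak end of what can be seen here. Compound 2 thus stands at the limit of > 100000 nM in this assay, at which 2 of the 3 values shown sit, with no number of its own to compare against.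

The new compound 4 `C[Si](C)(C)c1cn(C[C@H](O)[C@H]2OC(=O)C(OCc3ccccc3)=C2OCc2ccccc2)nn1` keeps the shared core of compound 2 and changes only the substituent on the triazole: a group of 4 heavy atoms (3 carbon, 1 silicon; no ring) in place of a group of 7 heavy atoms (6 carbon, 1 oxygen; one six-membered aromatic ring of carbon only), on an aromatic carbon. Going by the values given here, no measured step between two compounds is available to calibrate this change, so the expectation rests on the fact that compound 2 shows no activity down to the limit. Compound 4 is expected near 100000 nM, in the range 30000 nM to 300000 nM. The expected step of a number no higher from compound 2 to compound 4 (the limit leaves the size open) is none beyond the scatter.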

Compound 4, half-maximal inhibitory concentration: 56000 nM
For compound 4 the middle estimate is 1.8-fold (0.25 log units) above the measured one, within the range that was stated.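

Compound 4 shows that this aromatic carbon can carry a group of 4 heavy atoms with no ring, no hydrogen-bond donor and no hydrogen-bond acceptor, and the cells still give a real number rather than a limit. The 3-hydroxyphenyl group is therefore not needed for a readable value in this assay, where the swap gives an at least 1.7-fold lower number from compound 2 to compound 4 (0.25 log units; that floor lies within the scatter). The true size of that step remains unknown, since one end of it is only a limit: the limit of > 100000 nM in this assay, at which 2 of the 4 values shown sit.

Going by these compounds, whether the silicon atom itself matters remains open, and a tert-butyl group, with carbon in place of silicon, would be the direct comparison. Also open, on these data alone, is how an amine, a carboxylic acid or a longer alkyl chain at this position would read.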